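A few compounds are considered here, and "the series" means these few. Any claim that something is new, unique, unknown or untested is made for them only; others in the source may bear on it.

Measured so far:
Compound 1 `CCc1ccc2oc(CSc3nnc(CNc4ccccc4)n3CC)nc2c1`; in an assay on isolated protein for inhibition of long-chain fatty acid transport protein 1 (Mus musculus) (on this read-out higher numbers stand for weaker inhibition and lower numbers for stronger inhibition), compound 1 gives 1800 nM.
Compound 2 `CCC(=O)c1ccc2nc(CSc3nnc(CNc4ccccc4)n3CC)oc2c1`; in this assay compound 2 gives 1200 nM.

Only these two numbers exist, and compound 1 and compound 2 lie within the usual scatter of each other, so neither can be called stronger. Compound 3 `CCn1c(CNc2ccccc2)nnc1SCc1nc2cc(Cl)ccc2o1` differs from compound 1 by chloro in place of ethyl on an aromatic carbon. Among the measured compounds shown here, no pair of measured compounds shows what such a swap does, so the step expected from compound 1 to compound 3 is a 1.1-fold lower number from compound 1 to compound 3 (0.05 log units; within the scatter), nothing beyond the scatter in either direction. Compound 3 is therefore estimated at 1600 nM, with a range from 500 nM to 5000 nM.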

Compound 3, half-maximal inhibitory concentration: 2300 nM
Estimate against measurement, compound 3: 1.4-fold (0.16 log units) below; low and high end bracket the measured number.
By their numbers in this assay, from the lowest: compounds 2, 1 and 3 (each within the scatter of the next).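

Putting chloro in place of ethyl on this aromatic carbon gives a 1.3-fold higher number from compound 1 to compound 3 (0.11 log units; within the scatter) in this assay and so stays within the scatter. For this one pair, the swap leaves the read-out effectively unchanged, so this position tolerates either group on the core of compound 1. No measurement at hand offers an explanation for this.

Still open, as far as these compounds go, is whether this position ever matters: a single flat step cannot say. An amine, a carboxylic acid or a longer chain on the same carbon could behave quite differently.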